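3-Nitrophenyl to 4-Methoxyphenyl on a Saturated Ring Carbon

A few compounds are considered here, and "the series" means these few. Any claim that something is new, unique, unknown or untested is made for them only; others in the source may bear on it.

Of the compounds shown here, three built on one shared core have been read in an ADME assay on Vero cells (Chlorocebus sabaeus) for cytotoxicity, read by MTT assay, with a stated time of 72 h; on this read-out lower numbers stand for stronger inhibition and higher numbers for weaker inhibition. Compound 2, `O=C(c1ccncc1)N1N=C(c2cc3ccccc3o2)CC1c1cccc([N+](=O)[O-])c1`, gives > 240000 nM, which is a limit and not a number. Compound 1, `COc1ccccc1C1CC(c2cc3ccccc3o2)=NN1C(=O)c1ccncc1`, gives > 202000 nM, which is likewise a limit. Compound 3, `O=C(c1ccncc1)N1N=C(c2cc3ccccc3o2)CC1c1ccc(Cl)cc1`, gives > 220000 nM, again a limit. Compound 2 therefore has no numerical value to stand on, and neither of its two neighbours offers one.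

Compound 4, `COc1ccc(C2CC(c3cc4ccccc4o3)=NN2C(=O)c2ccncc2)cc1`, is still unmeasured. The change from compound 2 is 4-methoxyphenyl in place of 3-nitrophenyl on a saturated ring carbon.

Three measured steps exchange the aryl group at this same carbon. Going by the values given here, the first is a step that the two limits leave unreadable from compound 1 to compound 2. The second is a step that the two limits leave unreadable from compound 1 to compound 3. The third is a step that the two limits leave unreadable from compound 2 to compound 3. None of them has a readable size, so they offer no direction and no magnitude to carry over. All three compounds ended as limits in this assay, so no step beyond the scatter is expected here in either direction, and compound 4 may well return only a limit too. The expected change is an at least 1.0-fold lower number from compound 2 to compound 4 (0.03 log units; that floor lies within the scatter). For compound 4 the estimated value is 220000 nM, with an expected range from 100000 nM to 400000 nM.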

Compound 4, half-maximal inhibitory concentration: > 200000 nM
Compound 4: a limit, no number (the forecaster's own chance of this, stated with the estimate: 85%); the middle value lies beyond the limit too.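

In this assay compound 4 gives > 200000 nM, which is a limit and not a number. Compound 1, compound 2 and compound 3 also stand only as limits, and none of the steps linking them to compound 4 can be read. The compounds shown leave open whether exchanging the aryl group on this saturated ring carbon changes the read-out at all.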